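The compounds below may be only part of what the source reports. "The series", "measured", "known", "first", "only" and "open" are said of these compounds alone.

In an assay on isolated protein for activation of Insulin-degrading enzyme (Homo sapiens), read by fluorescence, with stated times of 10 min and 20 min (on this read-out higher numbers stand for an effect only at larger amounts of compound and lower numbers for an effect already at smaller amounts), compound 1 `O=C(CCCc1cn(S(=O)(=O)c2cccs2)c2ccccc12)NCCCn1ccnc1` gives 5500 nM; 5010 nM (2 entries). Compound 2 `CS(=O)(=O)n1cc(CCCC(=O)NCCCn2ccnc2)c2ccccc21` gives 26900 nM in this assay, and compound 3 `Cn1cnc(S(=O)(=O)n2cc(CCCC(=O)NCCCn3ccnc3)c3ccccc32)c1` gives 28800 nM. On these numbers compound 3 stands highest of the two single values, with compound 2 nearest at a distance that lies within the scatter; compound 1 gives the lower numbers, as its repeated entries the several entries of compound 1 in this assay, 5500 nM; 5010 nM (2 entries) show. Among the measured compounds shown here, the only step measured in one place is a 1.1-fold higher number from compound 2 to compound 3 (0.03 log units; within the scatter), where 1-methyl-1H-imidazol-4-yl took the place of methyl on the sulfonyl sulfur. Compound 4 `O=C(CCCc1cn(S(=O)(=O)c2cccnc2)c2ccccc12)NCCCn1ccnc1` differs from compound 3 by pyridin-3-yl in place of 1-methyl-1H-imidazol-4-yl on a sulfonyl sulfur. For the measured compounds named here, no measured step exchanges one aromatic group for another on the sulfonyl sulfur, so the step from compound 2 to compound 3 bears on it only in showing that a change at this sulfur can leave the number within the scatter, while the values of compound 1 show that a different aromatic group there goes with a lower number. The step is therefore expected to be modest, as a 2.4-fold lower number from compound 3 to compound 4 (0.38 log units; beyond the scatter), toward a lower number. For compound 4 the estimate in this assay is 12000 nM, with a range from 4000 nM to 35000 nM.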

Compound 4, half-maximal effective concentration: 26900 nM
Compound 4: middle estimate off by 2.2-fold (0.35 log units), on the low side, and the stated range covers the measured number.
By their numbers in this assay, from the lowest: compounds 2, 4 and 3 (each within the scatter of the next).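

In this assay, pyridin-3-yl in place of 1-methyl-1H-imidazol-4-yl gives a 1.1-fold lower number from compound 3 to compound 4 (0.03 log units; within the scatter), and the comparison with the methyl group gives no change at the digits printed from compound 2 to compound 4 (within the scatter). This shows that an aromatic group on the sulfonyl sulfur does not by itself go with a lower number, as methyl, 1-methyl-1H-imidazol-4-yl and pyridin-3-yl cannot be told apart on this read-out. Compound 1 goes against any broader link between aromatic groups and lower numbers, and its lower values remain alone among the compounds shown: the several entries of compound 1 in this assay, 5500 nM; 5010 nM (2 entries).

From the compounds shown here alone, it remains open whether a plain phenyl group on the sulfonyl sulfur would share the lower numbers of compound 1. Also open, going by these compounds, is whether an amine or a carboxylic acid on the pyridin-3-yl group would move the number beyond the scatter.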